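The compounds below may be only part of what the source reports. "The series", "measured", "known", "first", "only" and "open" are said of these compounds alone.

For the measured compounds named here, compound 1 `COc1ccccc1/C=c1/[nH]c(=O)/c(=C\c2ccccc2OC)n(C)c1=O` is the one compound here with a measured number: in a functional assay on K562 cells (Homo sapiens) for cytotoxicity, read by CCK-8 assay, with a stated time of 72 h (a higher number here means a weaker inhibitor, a lower number a stronger inhibitor), compound 1 gives 2200 nM. Its close relative compound 2 `COc1ccccc1/C=c1/[nH]c(=O)/c(=C\c2ccccc2OC)[nH]c1=O` is recorded in this assay as "not active" (no number reported), with no number attached, so compound 1 stands alone on the numbers shown. Compound 3 `COc1ccccc1/C=c1\c(=O)[nH]/c(=C/c2ccccc2Cl)c(=O)n1C` differs from compound 1 in one place: chloro in place of methoxy on an aromatic carbon. Going by the values given here, with no measured step of this kind to lean on, the expected change from compound 1 to compound 3 is a 1.1-fold lower number from compound 1 to compound 3 (0.04 log units; within the scatter), a step that stays within the usual scatter. Compound 3 is therefore estimated at 2000 nM, with a range from 700 nM to 6000 nM.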

Compound 3, half-maximal inhibitory concentration: 110 nM
The estimate for compound 3 lay 18-fold (1.26 log units) above the measured number, and the stated range ends above it.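

In this assay, chloro in place of methoxy gives a 20-fold lower number from compound 1 to compound 3 (1.30 log units; beyond the scatter) and so shows that this place on the aromatic ring responds strongly: turning 2-methoxyphenyl into 2-chlorophenyl, one change on the core of compound 1, moves the number well past the scatter. No evidence at hand explains this shift. The compounds shown leave open whether fluoro, bromo, methyl or an amine at this place would give a similar step. They also leave open whether chloro in place of the remaining methoxy would lower the number further.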